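This account rests on a few compounds, and the source may have more. Where it says the series, first, only, none or still open, it means among the compounds named here.

Measured compounds:
Compound 1, `CN1C/C(=C\c2cccnc2)C(=O)/C(=C/c2ccc(F)cc2Br)C1`, gives 2610 nM in a functional assay on QGY-7703 cells (Homo sapiens) for cytotoxicity, read by MTT assay, with a stated time of 24 h; on this read-out lower numbers stand for stronger inhibition and higher numbers for weaker inhibition.
Compound 2, `CN1C/C(=C\c2ccncc2)C(=O)/C(=C/c2ccc(F)cc2Br)C1`, gives 6900 nM in this assay.
Compound 3, `O=C1/C(=C/c2cccnc2)CNC/C1=C\c1ccccc1F`, gives 8890 nM in this assay.

Compounds 1 and 2 share one core and differ in a single place. The change from compound 1 to compound 2 is pyridin-4-yl in place of pyridin-3-yl on a double-bonded chain carbon bound to a double-bonded ring carbon and it brings a 2.6-fold higher number from compound 1 to compound 2 (0.42 log units; beyond the scatter), a step that lies beyond the usual scatter of repeated measurements.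

Compound 3 carries a different core. The difference between the core of compound 3 and the core of compound 1 is not broken down here. In this assay compound 3 gives 8890 nM, a number close to that of compound 2 and within the scatter of it, while its gap to compound 1 lies beyond the scatter.

Compound 4, `O=C1/C(=C/c2ccncc2)CNC/C1=C\c1ccccc1F`, has not yet been measured. It differs from compound 3 by pyridin-4-yl in place of pyridin-3-yl on a double-bonded chain carbon bound to a double-bonded ring carbon, the same change, at the same place, that leads from compound 1 to compound 2.

Because the matching change gave a 2.6-fold higher number from compound 1 to compound 2 (0.42 log units; beyond the scatter), compound 4 is expected to sit at a higher number than compound 3, with a step estimated at a 2.2-fold higher number from compound 3 to compound 4 (0.35 log units; beyond the scatter). The estimate rests on a single earlier step made on another core, so it is held loosely. Compound 4 is expected to give about 20000 nM in this assay, most likely between 8000 nM and 50000 nM.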

Compound 4, half-maximal inhibitory concentration: 14200 nM
Estimate against measurement, compound 4: 1.4-fold (0.15 log units) above; the measured number falls inside the stated range.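

In this assay the swap of pyridin-3-yl for pyridin-4-yl on the second core brings a 1.6-fold higher number from compound 3 to compound 4 (0.20 log units; within the scatter) and so, taken alone, cannot be told apart from the scatter of repeated measurements. Set beside the earlier step, it gives no sign that the change acts differently on the two cores, and the two steps agree as far as such measurements can tell: the same change on two cores in this assay, a 2.6-fold higher number (0.42 log units; beyond the scatter) from compound 1 to compound 2 and a 1.6-fold higher number (0.20 log units; within the scatter) from compound 3 to compound 4, 1.7-fold (0.22 log units) apart, within the scatter of two such steps
This is agreement within the noise on one pair of cores and does not prove that the change carries over, since only the first of the two steps stands clear of the scatter, and neither its true size nor its behaviour on any further core is settled.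

The compounds shown place only pyridin-3-yl and pyridin-4-yl on a double-bonded chain carbon bound to a double-bonded ring carbon, so it stays open how pyridin-2-yl or a plain phenyl group would read there on either core. Also open, on these data alone, is which of the differences between the two cores, among them the bromo and methyl groups that only the first core carries, governs the size of the step.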